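The source may hold more compounds than are shown below. What is called first, only, known or untested is meant among the compounds shown, and "the series" means these compounds.

Series notes. In a functional assay on the whole organism for inhibition, with Scenedesmus acutus as the target (a lower number here means a stronger inhibitor, a higher number a weaker inhibitor), compound 2 `COC(=O)CSc1cc(/N=c2\sc(=S)n3n2CCCC3)c(F)cc1Cl` gives 245 nM, the highest number among the three compounds measured. Compound 1 `S=c1n(-c2ccc(Cl)cc2)c(=S)n2n1CCCC2` gives 61.7 nM in this assay, and compound 3 `CC(C)Oc1cc(-n2c(=S)n3n(c2=S)CCCC3)c(F)cc1Cl` gives 7.59 nM; both lie below compound 2 by more than the scatter, compound 3 by the wider margin. Compound 4 `Fc1cc(Cl)ccc1/N=c1\sc(=S)n2n1CCCC2` has not yet been measured. Against compound 2 it shows (hydrogen in place of ((methoxycarbonyl)methyl)sulfanyl on an aromatic carbon), the position being ortho to a chloro group and para to a fluoro group. Going by the values given here, no measured pair differs in one place only, so the size of this step is not fixed by the data; compounds 1 and 3, which carry no ((methoxycarbonyl)methyl)sulfanyl group, both give the lower numbers. A moderate gain is expected, a 3.1-fold lower number from compound 2 to compound 4 (0.49 log units; beyond the scatter). Compound 4 is estimated at 80 nM, within a range from 20 nM to 300 nM.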

Compound 4, half-maximal inhibitory concentration: 120 nM
Compound 4: middle estimate off by 1.5-fold (0.18 log units), on the low side, within the range that was stated.
By their numbers in this assay, from the lowest: compound 3; then compounds 1 and 4 (each within the scatter of the next); then compound 2.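

Hydrogen in place of ((methoxycarbonyl)methyl)sulfanyl gives a 2.0-fold lower number from compound 2 to compound 4 (0.31 log units; beyond the scatter) in this assay and is the first single-place reading at this position, ortho to a chloro group and para to a fluoro group. The ((methoxycarbonyl)methyl)sulfanyl group is therefore not needed for inhibition in this pair, and the bare aromatic carbon gives the lower number. From the compounds shown here alone, whether an amine, a carboxylic acid or a longer thioether chain at this position would give a lower number than hydrogen remains open. Nothing in the data on hand accounts for the size of this step.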